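Lengthening a short amino chain: expected cytotoxicity of compound 4

A few compounds are considered here, and "the series" means these few. Any claim that something is new, unique, unknown or untested is made for them only; others in the source may bear on it.

Compound 1 `CC(C)Nc1nc(Nc2ccc(C#N)cc2)nc(Oc2ccc3cc(Br)ccc3c2Br)n1`: >= 209000 nM
Compound 2 `CCCNc1nc(Nc2ccc(C#N)cc2)nc(Oc2ccc3ccccc3c2Br)n1`: > 263000 nM
Compound 3 `CCNc1nc(Nc2ccc(C#N)cc2)nc(Oc2ccc3ccccc3c2Cl)n1`: 188000 nM

Among the measured compounds shown here, in an ADME assay on MT4 cells (Homo sapiens) for cytotoxicity, read by MTT assay, with a stated time of 4 days (on this read-out lower numbers stand for higher toxicity in this test and higher numbers for lower toxicity in this test), compound 3 gives 188000 nM, the only outright number among the three. Compound 1 stops at an assay limit, (the limit of >= 209000 nM in this assay, at which 1 of the 3 values shown sits). Compound 2 likewise stops at an assay limit, (the limit of > 263000 nM in this assay, at which 1 of the 3 values shown sits). All three compounds therefore sit in the same, very weakly toxic region of this assay.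

Compound 4 `CCCNc1nc(Nc2ccc(C#N)cc2)nc(Oc2ccc3ccccc3c2Cl)n1` differs from compound 3 by methyl in place of hydrogen on a saturated chain carbon, two bonds along the chain from a nitrogen on an aromatic ring. For the measured compounds named here, no measured pair isolates exactly this change, so the expectation rests on the shared picture of low toxicity. The step expected in this assay a 1.1-fold higher number from compound 3 to compound 4 (0.03 log units; within the scatter) is none beyond the usual scatter. Compound 4 is thus estimated at 200000 nM, within 100000 nM to 400000 nM, with a fair chance that only a limit is reported.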

Compound 4, half-maximal cytotoxic concentration: > 290000 nM
Compound 4: no number, only a limit; the forecaster's own chance of this, stated with the estimate: 50%; at least 1.4-fold (0.16 log units) between middle value and limit.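

Ethylamino to propylamino gives the first comparison here of two compounds that differ in one place, and in this assay it reads as an at least 1.5-fold higher number from compound 3 to compound 4 (0.18 log units; that floor lies within the scatter). On these data alone, compound 4 gives only a limit, so this floor is all that can be read, and the true size of the step stays unknown. The step for chloro in place of bromo cannot be read, since compound 2 and compound 4 both stop at limits. The compounds shown leave open how this assay would respond to butylamino, a longer chain, or to a chain carrying a carboxylic acid in place of propylamino.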